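This account rests on a few compounds, and the source may have more. Where it says the series, first, only, none or still open, it means among the compounds named here.

Two compounds of the series carry numbers in an assay on isolated protein for inhibition of Amine oxidase [flavin-containing] B (Bos taurus); on this read-out higher numbers stand for weaker inhibition and lower numbers for stronger inhibition. Compound 1 `C=CCN1CC=C(c2ccccc2)CC1` gives 268000 nM. Compound 2 `C=CC1=CCN(C)CC1` gives 330000 nM, the highest of the two numbers shown, with compound 1 nearest at a gap within the scatter. Compound 3 `C#CC1=CCN(C)CC1` differs from compound 2 by ethynyl in place of vinyl on a double-bonded ring carbon. Within the data shown here, no step between measured compounds is available for comparison, so no direction can be read from the data. Compound 3 is expected to show a step of a 1.3-fold lower number from compound 2 to compound 3 (0.12 log units; within the scatter), not beyond the scatter. Compound 3 is accordingly estimated at 250000 nM, with a range from 80000 nM to 800000 nM.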

Compound 3, inhibition constant: 154000 nM
Beside the measured number, compound 3's estimate is 1.6-fold (0.21 log units) above it, and the stated range covers the measured number.
By their numbers in this assay, from the lowest: compounds 3, 1 and 2 (each within the scatter of the next, the first and the last beyond it).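

In this assay, among these compounds, ethynyl in place of vinyl on the double-bonded ring carbon gives a 2.1-fold lower number from compound 2 to compound 3 (0.33 log units; beyond the scatter) as the first readable step. The step is modest, but it shows that the read-out responds to a change at this position even when the heavy-atom count stays the same. Nothing at hand bears on the cause of this step.

As far as these compounds go, it remains open how a nitrile, a propyl chain or a longer alkyne would read at this position. From the compounds shown here alone, it also remains open whether ethynyl gives a step of similar size on the core of compound 1.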